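Pyridinyl for ethyl on the piperazine nitrogen, series notes

A few compounds are considered here, and "the series" means these few. Any claim that something is new, unique, unknown or untested is made for them only; others in the source may bear on it.

The three measured compounds share one core and differ only in the ring at the end of the chain: compound 1 `COc1cc2c(Nc3ccc(C#N)cc3)ncnc2cc1OCCCN1CCC(O)CC1`, compound 2 `COc1cc2c(Nc3ccc(C#N)cc3)ncnc2cc1OCCCN1CCC(CO)CC1` and compound 3 `CCN1CCN(CCCOc2cc3ncnc(Nc4ccc(C#N)cc4)c3cc2OC)CC1`. In a functional assay on SH-SY5Y cells (Homo sapiens) for antiproliferative activity, read by MTT assay, with a stated time of 72 h (on this read-out higher numbers stand for weaker inhibition and lower numbers for stronger inhibition), compound 1 gives only a limit, > 100000 nM; this is the limit of > 100000 nM in this assay, at which 1 of the 3 values shown sits. Compound 2 gives 21600 nM in this assay. Compound 3 gives 5440 nM, the lowest of the two numbers shown. The steps read an at least 4.6-fold lower number from compound 1 to compound 2 (0.66 log units; beyond the scatter), an at least 18-fold lower number from compound 1 to compound 3 (1.26 log units; beyond the scatter) and a 4.0-fold lower number from compound 2 to compound 3 (0.60 log units; beyond the scatter); all three exchange the ring itself, including its hetero atom and its polar group.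

Compound 4 `COc1cc2c(Nc3ccc(C#N)cc3)ncnc2cc1OCCCN1CCN(c2ccncc2)CC1` keeps the piperazine of compound 3 and carries pyridin-4-yl in place of ethyl on an amine nitrogen in a ring. Among the compounds with values here, none of the measured steps touches a group on that far nitrogen, so none bears directly on this change; the only comparison is that the two piperidine variants, compound 1 and compound 2, and the piperazine of compound 3 differ in the ring rather than in a substituent on it. Within the data shown here, with no step to lean on, the expectation in this assay is no change beyond the scatter, the estimated step being a 1.1-fold higher number from compound 3 to compound 4 (0.04 log units; within the scatter). Compound 4 is therefore expected to give about 6000 nM, between 1800 nM and 25000 nM.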

Compound 4, half-maximal inhibitory concentration: 31600 nM
Estimate against measurement, compound 4: 5.3-fold (0.72 log units) below; measured number outside the range, above it.
By their numbers in this assay, from the lowest: compound 3; then compounds 2 and 4 (each within the scatter of the next). At a limit, above all of these: compound 1.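

The far nitrogen of the piperazine is not indifferent to its substituent in this assay: the only step shown at this position reads a 5.8-fold higher number from compound 3 to compound 4 (0.76 log units; beyond the scatter), so replacing ethyl with pyridin-4-yl gives up the standing that compound 3 holds in the series. The steps that exchange the whole ring end read a 1.5-fold higher number from compound 2 to compound 4 (0.17 log units; within the scatter), which leaves the 4-(pyridin-4-yl)piperazin-1-yl and 4-(hydroxymethyl)piperidin-1-yl ends indistinguishable here, and an at least 3.1-fold lower number from compound 1 to compound 4 (0.50 log units; beyond the scatter), which rests on a limit for compound 1 and not on a number. Nothing shown bears on the reason for the step from ethyl to pyridin-4-yl.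

On these data alone, with only ethyl and pyridin-4-yl on this nitrogen, it remains open whether a methyl, a longer alkyl chain or a benzyl group would read like compound 3 or like compound 4. As far as these compounds go, a phenyl group and a pyridin-3-yl group would show whether the step follows the aromatic ring itself or the place of its ring nitrogen, and whether either reading carries over to other cell lines also remains open.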